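The source may hold more compounds than are shown below. What is called first, only, known or untested is meant among the compounds shown, and "the series" means these compounds.

Compound 1 `Oc1ccc(-c2cc(-c3cccc(O)c3)cc(-c3ccc(O)cc3)n2)cc1`: in a functional assay on HCT-15 cells (Homo sapiens) for cytotoxicity, read by CCK-8 assay, with a stated time of 4 days (on this read-out higher numbers stand for weaker inhibition and lower numbers for stronger inhibition), compound 1 gives > 50000 nM, a limit of the assay. Compound 2 `Oc1ccc(-c2cc(-c3ccccc3O)cc(-c3ccc(O)cc3)n2)cc1`: compound 2 gives 1920 nM. Compound 3 `Oc1ccc(-c2cc(-c3ccccc3O)nc(-c3ccccc3O)c2)cc1`: compound 3 gives > 50000 nM, again a limit.

Compounds 2 and 1 differ by one change, (3-hydroxyphenyl in place of 2-hydroxyphenyl on an aromatic carbon). This change made an at least 26-fold higher number from compound 2 to compound 1 (1.41 log units; beyond the scatter). Compound 3 has a different core, and the difference between the two cores is not broken down here. Compound 4 `Oc1ccc(-c2cc(-c3cccc(O)c3)nc(-c3ccccc3O)c2)cc1` arises from compound 3 by the same kind of change, (3-hydroxyphenyl in place of 2-hydroxyphenyl on an aromatic carbon); here the carbon is next to the ring nitrogen, meta to a 2-hydroxyphenyl group and meta to a 4-hydroxyphenyl group, whereas in compound 2 it is opposite the ring nitrogen, meta to two 4-hydroxyphenyl groups. Since compound 3 already sits at the limit of > 50000 nM in this assay, at which 2 of the 3 values shown sit, any further weakening cannot appear as a number. The expected step is a step that the limit leaves unreadable from compound 3 to compound 4. Compound 4 is expected to give 60000 nM in this assay, between 20000 nM and 200000 nM.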

Compound 4, half-maximal inhibitory concentration: 5830 nM
Compound 4: middle estimate off by 10-fold (1.01 log units), on the high side; the measured number lies below the stated range.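

In this assay, putting 3-hydroxyphenyl in place of 2-hydroxyphenyl gave an at least 8.5-fold lower number from compound 3 to compound 4 (0.93 log units; beyond the scatter), the opposite direction to an at least 26-fold higher number from compound 2 to compound 1 (1.41 log units; beyond the scatter). The effect of this change therefore did not carry over from one core to the other, and the two steps clearly part: the same change on two cores in this assay, an at least 26-fold higher number (1.41 log units; beyond the scatter) from compound 2 to compound 1 and an at least 8.5-fold lower number (0.93 log units; beyond the scatter) from compound 3 to compound 4, at least 220-fold (2.34 log units) apart, beyond the scatter of two such steps. Each step rests on a limit rather than a number, so the steps show direction and a minimum size only, and they do not show why the two cores respond differently: the limit of > 50000 nM in this assay, at which 2 of the 4 values shown sit.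

The compounds shown leave open whether this contrast would hold with an amine or a methoxy group in place of the hydroxyl on the exchanged ring. They also leave open how a 4-hydroxyphenyl group would compare on the same carbon in each core.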